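A few compounds are considered here, and "the series" means these few. Any claim that something is new, unique, unknown or untested is made for them only; others in the source may bear on it.

Measured compounds:
compound 1, `CNC(=O)c1cc(Oc2ccc(NC(=O)c3nn(-c4ccccc4C(F)(F)F)c(=O)cc3C)cc2F)ccn1`, > 40000 nM in a functional assay on A549 cells (Homo sapiens) for cytotoxicity, read by MTT assay, with a stated time of 72 h; on this read-out lower numbers stand for stronger inhibition and higher numbers for weaker inhibition
compound 2, `CNC(=O)c1cc(Oc2ccc(NC(=O)c3nn(-c4ccc(Br)cc4F)c(=O)cc3C)cc2F)ccn1`, 7930 nM
compound 3, `CNC(=O)c1cc(Oc2ccc(NC(=O)c3nn(-c4ccccc4OC(F)(F)F)c(=O)cc3C)cc2F)ccn1`, > 40000 nM

Compound 3 stands at a limit of the assay rather than at a number; it shares this with compound 1, as the limit of > 40000 nM in this assay, at which 2 of the 3 values shown sit, records. Only compound 2, carrying the 4-bromo-2-fluorophenyl group, gives a numerical value. The step of an at least 5.0-fold higher number from compound 2 to compound 3 (0.70 log units; beyond the scatter) shows the cost of the 2-(trifluoromethoxy)phenyl group, and an at least 5.0-fold lower number from compound 1 to compound 2 (0.70 log units; beyond the scatter) shows the matching gain when another group bearing a 2-(trifluoromethyl)phenyl is replaced by the 4-bromo-2-fluorophenyl group. Compound 4, `CNC(=O)c1cc(Oc2ccc(NC(=O)c3nn(-c4ccc(C)cc4)c(=O)cc3C)cc2F)ccn1`, has not yet been measured. It differs from compound 3 by 4-methylphenyl in place of 2-(trifluoromethoxy)phenyl on an aromatic nitrogen. The step from compound 3 to compound 4 is expected to run toward a lower number, as in an at least 5.0-fold lower number from compound 1 to compound 2 (0.70 log units; beyond the scatter), although only compound 2 supports this and its size cannot be fixed from a limit. Compound 4 is therefore estimated at 9000 nM, within 2500 nM to 40000 nM, a step of an at least 4.4-fold lower number from compound 3 to compound 4 (0.64 log units; beyond the scatter).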

Compound 4, half-maximal inhibitory concentration: 11500 nM
For compound 4 the middle estimate is 1.3-fold (0.11 log units) below the measured one; the measured number falls inside the stated range.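

In this assay, compound 4 shows that a readable value at this aromatic nitrogen does not depend on the 4-bromo-2-fluorophenyl group or on any halogen: the change to 4-methylphenyl gives a 1.5-fold higher number from compound 2 to compound 4 (0.16 log units; within the scatter), so the two groups cannot be told apart here. The same group also separates clearly from both groups that gave no number, with an at least 3.4-fold lower number from compound 3 to compound 4 (0.54 log units; beyond the scatter) and an at least 3.4-fold lower number from compound 1 to compound 4 (0.54 log units; beyond the scatter), yet compound 2 also carries fluorine, so fluorine alone does not mark the compounds without a number. Those two steps are bounds and not sizes, since compound 1 and compound 3 remain at a limit: the limit of > 40000 nM in this assay, at which 2 of the 4 values shown sit.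

What the compounds leave open is whether a plain phenyl, or an amine or a carboxylic acid on the ring, would move the value away from that of compound 2 and compound 4. As far as these compounds go, it is equally open what a longer alkyl chain in place of the ring would do.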